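The source may hold more compounds than are shown below. What is called first, only, known or untested is meant among the compounds shown, and "the series" means these compounds.

Of the compounds shown here, three sharing one core have been tested in a toxicity assay on MDCK cells (Canis lupus familiaris) for cytotoxicity, read by crystal violet staining, with a stated time of 48 h; on this read-out higher numbers stand for lower toxicity in this test and lower numbers for higher toxicity in this test. Compound 1, `CCCc1ccc2[nH]c(=O)c(CN(Cc3ccc(F)cc3)Cc3ccc(C(C)(C)C)cc3)cc2c1`, gives 8400 nM. Compound 2, `Cc1ccc2[nH]c(=O)c(CN(CCCO)Cc3ccc(C(C)(C)C)cc3)cc2c1`, reaches only a limit of the assay, > 10000 nM. Compound 3, `CCc1ccc2[nH]c(=O)c(CN(CCCO)Cc3ccc(C(C)(C)C)cc3)cc2c1`, likewise reaches only a limit, > 10000 nM. Among the compounds with values here, the single step between measured neighbours, a step that the two limits leave unreadable from compound 2 to compound 3, is therefore of unknown size, since both of its ends sit at the limit of > 10000 nM in this assay, at which 2 of the 3 values shown sit.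

Compound 4 is `Cc1ccc2[nH]c(=O)c(CN(Cc3ccc(C(C)(C)C)cc3)[C@H](C)c3ccc(F)cc3)cc2c1`. It differs from compound 2 by 1-(4-fluorophenyl)ethyl in place of 3-hydroxypropyl on an amine nitrogen. Within the data shown here, no measured step touches this position: the one step that exists changes the core and is hidden by limits. Among the measured compounds shown here, the only number in the set belongs to compound 1, which also carries an aromatic group on the amine nitrogen and gives 8400 nM. On that ground compound 4 is expected to land near the same region, estimated at 8000 nM with a range from 3000 nM to 20000 nM. The step of an at least 1.2-fold lower number from compound 2 to compound 4 (0.09 log units; that floor lies within the scatter) is thus expected to be modest and read against a limit.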

Compound 4, half-maximal cytotoxic concentration: > 5000 nM
Compound 4 ended at the assay's limit; the forecaster's own chance of this, stated with the estimate: 40%; the middle value lies beyond the limit too.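

Compound 4 gives > 5000 nM, which is a limit of the assay and not a number. Compound 2 also sits at a limit, so the step between the two cannot be read. From the compounds shown here alone, it remains open whether, and how far, 1-(4-fluorophenyl)ethyl in place of 3-hydroxypropyl shifts toxicity in this test.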